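Aryl enone series: phenyl to thiophen-2-yl on carbonyl

This account rests on a few compounds, and the source may have more. Where it says the series, first, only, none or still open, it means among the compounds named here.

Measured so far:
compound 1 `O=C(/C=C/c1cnn(-c2ccccc2)n1)c1ccccc1` gives 28600 nM
compound 2 `Cc1ccc(C(=O)/C=C/c2cnn(-c3ccccc3)n2)c(C)c1` gives 15600 nM
compound 3 `COc1ccc(C(=O)/C=C/c2cnn(-c3ccccc3)n2)c(OC)c1` gives 25600 nM

In a functional assay on PC-3 cells (Homo sapiens) for cytotoxicity, read by MTT assay, with a stated time of 24 h (a higher number here means a weaker inhibitor, a lower number a stronger inhibitor), compound 1 gives the highest of the three numbers, but its gaps to compound 3 and to compound 2 both lie within the scatter, so no order among the three can be read from these data. Compound 4 `O=C(/C=C/c1cnn(-c2ccccc2)n1)c1cccs1` differs from compound 1 in one place: thiophen-2-yl in place of phenyl on a carbonyl carbon. For the measured compounds named here, no pair of measured compounds shows this change, so its effect here is unknown. With the aryl variations at this position giving numbers within the scatter of one another, the step from compound 1 to compound 4 in this assay is expected to stay within the scatter, or to be small in the direction of a lower number. Compound 4 is estimated at 22000 nM, with a range of 8000 nM to 60000 nM, meaning an expected step of a 1.3-fold lower number from compound 1 to compound 4 (0.11 log units; within the scatter).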

Compound 4, half-maximal inhibitory concentration: 47900 nM
Compound 4: the middle estimate sits 2.2-fold (0.34 log units) below what was measured; the measured number falls inside the stated range.
By their numbers in this assay, from the lowest: compounds 2, 3, 1 and 4 (each within the scatter of the next, the first and the last beyond it).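

In this assay, thiophen-2-yl in place of phenyl on a carbonyl carbon gives a 1.7-fold higher number from compound 1 to compound 4 (0.22 log units; within the scatter), the first step read directly at this position. A five-membered aromatic ring with one hetero atom is therefore accepted here without a change that can be told from the scatter. No measurement shown bears on the cause of this result.

As far as these compounds go, whether a cyclohexyl or pyridyl group at this carbonyl carbon would give a step beyond the scatter remains open. From the compounds shown here alone, the effect of an amine elsewhere on the shared core also remains open.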